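Working notes: aryl variation on the shared core

The source may hold more compounds than are shown below. What is called first, only, known or untested is meant among the compounds shown, and "the series" means these compounds.

Measured compounds:
compound 1, `Cc1nc(N)sc1CCCN/C(N)=N/C(=O)NC(c1ccccc1)C(C)C`, 34.7 nM
compound 2, `Cc1nc(N)sc1CCCN/C(N)=N/C(=O)NC(C)c1ccc(OC(F)(F)F)cc1`, 724 nM
compound 3, `Cc1ccc(C(C)NC(=O)/N=C(\N)NCCCc2sc(N)nc2C)cc1`, 22.4 nM

In a functional assay on Right cardiac atrium for agonist activity at histamine H2 receptor (Cavia porcellus), with a stated time of 30 min, in the presence of a further agent that is not named here (on this read-out lower numbers stand for an effect already at smaller amounts and higher numbers for an effect only at larger amounts of compound), compound 3 gives the lowest number of the three measured, yet compound 1 sits within the scatter of it, so no order between compound 3 and compound 1 can be read; only compound 2 stands clearly apart, with a higher number.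

The new compound 4, `Cc1nc(N)sc1CCCN/C(N)=N/C(=O)NC(C)c1cccc(F)c1`, differs from compound 3 by 3-fluorophenyl in place of 4-methylphenyl on a saturated chain carbon bound to an amide-type nitrogen and a saturated chain carbon. Among the compounds with values here, the one measured step that touches the same aryl group is a 32-fold lower number from compound 2 to compound 3 (1.51 log units; beyond the scatter), which shows that a change on that ring can move the read-out far beyond the scatter. A fluorine in place of a methyl, and in a different position, is not the same change, so that step gives direction only loosely. The expectation is for a higher number than compound 3, smaller in size than the step seen from compound 2 to compound 3. For compound 4 the expected step is estimated as a 2.7-fold higher number from compound 3 to compound 4 (0.43 log units; beyond the scatter).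

Compound 4 is therefore estimated at 60 nM in this assay, with a range from 20 nM to 200 nM.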

Compound 4, half-maximal effective concentration: 26.3 nM
Compound 4: middle estimate off by 2.3-fold (0.36 log units), on the high side; measured number inside the range.
By their numbers in this assay, from the lowest: compounds 3, 4 and 1 (each within the scatter of the next); then compound 2.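

In this assay the exchange of 4-methylphenyl for 3-fluorophenyl gives a 1.2-fold higher number from compound 3 to compound 4 (0.07 log units; within the scatter) and so leaves the two numbers indistinguishable, while the earlier step, a 32-fold lower number from compound 2 to compound 3 (1.51 log units; beyond the scatter) on the same ring, had shown only that a change there can matter greatly. A large step is therefore not general for this aryl group: at this saturated chain carbon, 3-fluorophenyl and 4-methylphenyl cannot be told apart on this read-out, although the two groups differ both in the atom carried and in its ring position. Nothing available bears on why these two groups give such close numbers.

Fluorine and ring position are not separated here, so 4-fluorophenyl and 3-methylphenyl remain open. As far as these compounds go, it is also open whether an amine or a carboxylic acid on this ring would stay with compound 3 and compound 4 or stand apart as compound 2 does.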